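The source may hold more compounds than are shown below. What is called first, only, known or untested is meant among the compounds shown, and "the series" means these compounds.

Measured compounds in a functional assay on HEp-2 cells (Homo sapiens) for cytotoxicity, read by MTT assay, with a stated time of 72 h, tested at 2.5 ug/mL; a higher number here means more inhibition of growth at the concentration tested, a lower number less inhibition of growth:
- compound 1, `O=C1NC(=S)/C(=C/c2cc(Cl)cc(Cl)c2Cl)S1`: 21.8%
- compound 2, `O=C1NC(=S)/C(=C/c2ccccc2Br)S1`: 10.3%
- compound 3, `O=C1NC(=S)/C(=C/c2ccccc2Cl)S1`: -11.5%

Compound 3 stands lowest of the three numbers in this assay. Its nearest neighbour is compound 2, whose value is higher beyond the scatter, and compound 1 lies furthest above it. Among the compounds with values here, the only single-change step among the measured compounds is the one from compound 2 to compound 3, a number 21.8 percentage points lower from compound 2 to compound 3 (beyond the scatter), chloro in place of bromo on an aromatic carbon, and it is modest in size.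

The next compound, compound 4, `O=C1NC(=S)/C(=C/c2ccccc2F)S1`, differs from compound 3 by fluoro in place of chloro on an aromatic carbon. The measured step from compound 2 to compound 3 bears on this only loosely: it shows that exchanging one halogen for another at this position moved the number by a modest amount, and that the direction was downward. Within the data shown here, no step from chloro to fluoro has been measured, so its size is not known from the data. Taking the bromo-to-chloro step as a rough guide, a further small downward move, or none beyond the scatter, is expected in this assay.

For compound 4 the expected step from compound 3 is a number 3.5 percentage points lower from compound 3 to compound 4 (within the scatter), so compound 4 is estimated at -15%, with a range from -40% to 10%.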

Compound 4, percent growth inhibition at one concentration: 1.66%
Compound 4: the middle estimate sits 16.7 percentage points below what was measured, within the range that was stated.
By their numbers in this assay, from the lowest: compound 3; then compounds 4 and 2 (each within the scatter of the next); then compound 1.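

In this assay the change from chloro to fluoro gives a number 13.2 percentage points higher from compound 3 to compound 4 (beyond the scatter) and so runs against the earlier halogen step, which was a number 21.8 percentage points lower from compound 2 to compound 3 (beyond the scatter) when chloro replaced bromo at this same place, on an aromatic carbon ortho to a group of 8 heavy atoms. Read alongside these, a number 8.6 percentage points lower from compound 2 to compound 4 (within the scatter) separates the fluoro and bromo compounds by no more than the usual scatter, so among these three compounds with a single halogen the number does not follow the order fluoro, chloro, bromo: the chloro compound alone stands apart, below the other two by steps beyond the scatter. The series offers no measurement that speaks to why this halogen exchange behaves in this way.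

Three compounds at a single concentration in one cell line cannot show whether the low reading of the chloro compound is a lasting feature of this place or a feature of this one comparison. Also open, from the compounds shown here alone, is how a group other than a halogen, such as methoxy, an amine or a carboxylic acid, would read at the same ring carbon on the shared core.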